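The source may report more compounds than this note shows. Statements on the series, on what has been measured and on what is new or still open speak of the compounds shown alone.

In a functional assay on HCT-116 cells (Homo sapiens) for cytotoxicity, read by sulforhodamine B assay (on this read-out higher numbers stand for weaker inhibition of growth and lower numbers for stronger inhibition of growth), compound 3 `N#Cc1ccc(COC[C@H]2O[C@@H](n3c(NCc4ccc(Cl)c(Cl)c4)nc4c(N)ncnc43)[C@H](O)[C@@H]2O)cc1` gives 5000 nM, the lower of the two numbers available, while compound 1 `Nc1ncnc2c1nc(NCc1ccc(Cl)c(Cl)c1)n2[C@@H]1O[C@H](COCc2cc(F)c(F)c(F)c2)[C@@H](O)[C@H]1O` gives 13000 nM. Compound 2 `N#Cc1ccc(COC[C@H]2O[C@@H](n3c(NCc4ccc5ncccc5c4)nc4c(N)ncnc43)[C@H](O)[C@@H]2O)cc1` reads > 80000 nM, which is a limit. Compound 4 `N#Cc1ccc(COC[C@H]2O[C@@H](n3c(NCc4ccccc4)nc4c(N)ncnc43)[C@H](O)[C@@H]2O)cc1` carries phenyl in place of 3,4-dichlorophenyl on a saturated chain carbon bound to a nitrogen on an aromatic ring. The modest step of a 2.6-fold lower number from compound 1 to compound 3 (0.41 log units; beyond the scatter) lies at a different place and bears little on this change. The large step of an at least 16-fold lower number from compound 2 to compound 3 (1.20 log units; beyond the scatter) lies at the same place and is the closest guide, although it involves quinolin-6-yl rather than phenyl. A clear move to a higher number is therefore expected, an estimated 5.0-fold higher number from compound 3 to compound 4 (0.70 log units; beyond the scatter). For compound 4 the expected value is 25000 nM, within an estimated range of 9000 nM to 70000 nM.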

Compound 4, concentration for 50% growth inhibition: > 80000 nM
Compound 4 ended at the assay's limit; the forecaster's own chance of this, stated with the estimate: 20%; middle value at least 3.2-fold (0.50 log units) away from the limit.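

Phenyl in place of 3,4-dichlorophenyl gives an at least 16-fold higher number from compound 3 to compound 4 (1.20 log units; beyond the scatter), so the earlier drop with quinolin-6-yl was not special to that group. Among the compounds shown, only those carrying 3,4-dichlorophenyl at this place stay short of the limit in this assay, and compound 4 now gives the limit > 80000 nM. The step from compound 2 to compound 4 cannot be read, since both ends are limits: the limit of > 80000 nM in this assay, at which 2 of the 4 values shown sit.

From the compounds shown here alone, whether a single chlorine would keep the growth inhibition remains open. So does the effect of a methyl or methoxy group on the phenyl ring.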